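Compound 3 and its trichlorophenyl relative, compound 4

The compounds below may be only part of what the source reports. "The series", "measured", "known", "first", "only" and "open" are said of these compounds alone.

Of the compounds shown here, three sharing one core have been tested in a functional assay on DU-145 cells (Homo sapiens) for inhibition, read by trypan blue exclusion, with a stated time of 96 h; on this read-out higher numbers stand for weaker inhibition of growth and lower numbers for stronger inhibition of growth. There, compound 1 `O=C(/C(=C\c1ccc(O)cc1)SCc1ccc(Cl)cc1)c1ccc(Br)cc1` gives 10000 nM, compound 2 `COc1ccc(/C=C(/SCc2ccc(Cl)cc2)C(=O)c2ccc(Br)cc2)cc1O` gives 1000 nM and compound 3 `O=C(/C(=C\c1ccc(Cl)cc1)SCc1ccc(Cl)cc1)c1ccc(Br)cc1` gives 10000 nM. Compound 3 thus stands level with compound 1, the two together holding the highest number of the three.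

The next structure, compound 4 `O=C(/C(=C\c1cc(Cl)cc(Cl)c1Cl)SCc1ccc(Cl)cc1)c1ccc(Br)cc1`, carries 2,3,5-trichlorophenyl in place of 4-chlorophenyl on a double-bonded chain carbon bound to a double-bonded chain carbon.

Within the data shown here, two measured steps bear on this change. The swap of hydroxy for chloro, no change at the digits printed from compound 1 to compound 3 (within the scatter), lies within the scatter. Among the measured compounds shown here, the only sizeable change at this place, a 10-fold higher number from compound 2 to compound 3 (1.00 log units; beyond the scatter), removes the 3-hydroxy-4-methoxyphenyl group of compound 2, and compound 4 does not regain that group. For the measured compounds named here, no measured step adds further chloro groups to the ring.

Only a small shift is therefore expected in this assay, an estimated 1.4-fold lower number from compound 3 to compound 4 (0.15 log units; within the scatter), which stays within the scatter. The estimate for compound 4 is 7000 nM, with an expected range of 2000 nM to 20000 nM.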

Compound 4, concentration for 50% growth inhibition: 1000 nM
The estimate for compound 4 lay 7.0-fold (0.85 log units) above the measured number; the whole stated range lies above it.
By their numbers in this assay, from the lowest: compounds 2 and 4 (each within the scatter of the next); then compounds 1 and 3 (each within the scatter of the next).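

In this assay the step to 2,3,5-trichlorophenyl gives a 10-fold lower number from compound 3 to compound 4 (1.00 log units; beyond the scatter) and shows that a ring bearing only chloro groups can shift the number at this place, which the 4-chlorophenyl of compound 3 had not shown. The 3-hydroxy-4-methoxyphenyl group is thus not alone in giving the lower number here, for the swap to the trichlorophenyl group gives no change at the digits printed from compound 2 to compound 4 (within the scatter) while the swap from 4-hydroxyphenyl gives a 10-fold lower number from compound 1 to compound 4 (1.00 log units; beyond the scatter) on the same core. Nothing available explains why the added chloro groups go with this shift.

From the compounds shown here alone, it stays open which of the three chloro groups matters, and whether a dichlorophenyl or an aminophenyl group at this place would give a similar number. Going by these compounds, whether the shift holds when the 4-bromophenyl carbonyl part of the core is replaced also remains open.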